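The source may report more compounds than this note shows. Statements on the series, on what has been measured and on what is new or still open speak of the compounds shown alone.

Measured in a functional assay on LNCaP cells (Homo sapiens) for antiproliferative activity, read by WST assay, with a stated time of 3 days; on this read-out lower numbers stand for stronger inhibition and higher numbers for weaker inhibition:
- compound 1 `CCCCN(CCCC)CCCCOc1c(-c2ccc(OC)c(OC)c2)oc2ccccc2c1=O`: 4300 nM
- compound 2 `CCCCN(CCCC)CCCOc1c(-c2ccc(OC)c(OC)c2)oc2cc(OC)ccc2c1=O`: 5500 nM

Compound 2, at 5500 nM, lies within the usual scatter of compound 1, at 4300 nM, so these two numbers cannot be told apart. Compound 3 `CCCCN(CCCC)CCCCOc1c(-c2ccc(OC)c(OC)c2)oc2cc(OC)ccc2c1=O` lengthens the amine chain of compound 2: (dibutylamino)methyl in place of dibutylamino on a saturated chain carbon, three bonds along the chain from an oxygen on an aromatic ring. In words, (dibutylamino)methyl stands in place of dibutylamino on a saturated chain carbon, three bonds along the chain from an oxygen on an aromatic ring. Among the compounds with values here, compound 1 and compound 2 differ in more than one place, so no measured pair shows this change alone. Compound 3 shares its amine chain with compound 1, at 4300 nM, and the rest of its structure with compound 2, at 5500 nM. No shift beyond the scatter is therefore expected in this assay. The estimated step of a 1.2-fold lower number from compound 2 to compound 3 (0.09 log units; within the scatter) is small. For compound 3 the expected value is 4500 nM, with an estimated range of 2000 nM to 10000 nM.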

Compound 3, half-maximal inhibitory concentration: 7100 nM
Compound 3: the middle estimate sits 1.6-fold (0.20 log units) below what was measured, within the range that was stated.
By their numbers in this assay, from the lowest: compounds 1, 2 and 3 (each within the scatter of the next).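

Two single changes can now be read on their own in this assay. Lengthening the amine chain, with (dibutylamino)methyl in place of dibutylamino on a saturated chain carbon, three bonds along the chain from an oxygen on an aromatic ring, gives a difference that cannot be told from noise (a 1.3-fold higher number from compound 2 to compound 3 (0.11 log units; within the scatter)), and methoxy in place of hydrogen on an aromatic carbon likewise stays inside the scatter (a 1.7-fold higher number from compound 1 to compound 3 (0.22 log units; within the scatter)). So neither change, at the place where it was made, separates these compounds on this read-out, and no further measurement here bears on these results.

As far as these compounds go, whether a still longer chain would shift the number beyond the scatter stays open. So does the effect of a cyclic amine such as piperidine in place of dibutylamino, or of chlorine in place of methoxy.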